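This account rests on a few compounds, and the source may have more. Where it says the series, first, only, none or still open, it means among the compounds named here.

Working notes on the series. Among the measured compounds shown here, compound 2 `C[C@H](Nc1ncnc(N)c1C#N)c1c(C2CC2)c(=O)n2cc(F)ccc2c1-c1ccc(F)cc1` is the only member with a number in an ADME assay on microsomes from liver (Homo sapiens), read by LC-MS, using NADPH, with a stated time of 30 min, tested at 1 uM; on this read-out higher numbers stand for a more stable compound and lower numbers for a less stable compound; in that assay compound 2 gives 93%, a high fraction left after the incubation. Compound 1 `C[C@H](Nc1nc(N)nc(N)c1C#N)c1cc(=O)n2cc(F)ccc2c1-c1ccc(F)cc1` also belongs to the set, but in this assay compound 1 gives "not determined" (no result reported), so compound 2 stands alone as the sole numerical point, with one further entry that carries no number. Compound 3 `C[C@H](Nc1nc(N)nc(N)c1C#N)c1c(C2CC2)c(=O)n2cc(F)ccc2c1-c1ccc(F)cc1` differs from compound 2 in a single place: amino in place of hydrogen on an aromatic carbon. For the measured compounds named here, because no pair of measured compounds differs in one place, there is no measured step in this assay to set a scale for this change. The change adds one nitrogen with a donor and an acceptor and leaves the rest of compound 2 untouched. The expectation for the change from compound 2 to compound 3 is a step of a number 5 percentage points lower from compound 2 to compound 3 (within the scatter), that is, nothing clearly beyond the usual scatter, with a slight downward lean only because compound 2 sits near the top of the read-out at 93%. Compound 3 is therefore expected to give about 88% in this assay, with a plausible range from 70% to 98%.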

Compound 3, percent of the compound remaining: 86%
Beside the measured number, compound 3's estimate is 2 percentage points above it; low and high end bracket the measured number.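

In this assay the series now has its first measured step, a number 7 percentage points lower from compound 2 to compound 3 (within the scatter), and it gives a scale for amino in place of hydrogen on this aromatic carbon, which lies between two ring nitrogen atoms and para to the cyano group. The 2,6-diamino-5-cyanopyrimidin-4-yl compound and the 6-amino-5-cyanopyrimidin-4-yl compound cannot be told apart on this read-out, so this position accepts the amino group with the fraction left after incubation remaining high, as compound 3 at 86% shows. Among the compounds shown here, nothing at hand accounts for this result, and the single step rests on one pair of compounds on the shared core.

Still open, from the compounds shown here alone, is whether a larger or differently bonded group at this carbon, such as methylamino, methoxy or a chlorine atom, would also stay within the scatter of compound 2. Going by these compounds, the step from compound 1 cannot be read, as compound 1 gives "not determined" (no result reported), so the contribution of the cyclopropyl group of compound 3 to stability on this read-out also remains open.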